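The source may hold more compounds than are shown below. What is called first, only, known or untested is meant among the compounds shown, and "the series" means these compounds.

Working notes on the series. In a functional assay on MDA-MB-231 cells (Homo sapiens) for antiproliferative activity, read by MTT assay, with a stated time of 72 h (a higher number here means a weaker inhibitor, a lower number a stronger inhibitor), compound 1 `NC1=NC2(CCOCC2)N(OCCCOc2ccc(F)cc2)C(N)=N1` gives "not determined" (no result reported) and compound 2 `Cc1ccc(OCCCON2C(N)=NC(N)=NC23CCOCC3)cc1` gives "not determined" (no result reported), so neither carries a reported result. Among the measured compounds shown here, compound 3 `NC1=NC2(CCOCC2)N(OCCCOc2ccccc2Br)C(N)=N1` is therefore the only member with a number: in this assay compound 3 gives 910 nM, and with nothing else measured it cannot be placed relative to any other member. Compound 4 `NC1=NC2(CCOCC2)N(OCCCOc2cccc(Br)c2)C(N)=N1` differs from compound 3 by 3-bromophenyl in place of 2-bromophenyl on an oxygen on a saturated carbon. For the measured compounds named here, no measured pair of this kind exists, so the size of this change is unknown. With only compound 3 as an anchor, the step from compound 3 to compound 4 is expected to stay within the scatter, in no particular direction, a 1.0-fold lower number from compound 3 to compound 4 (0.00 log units; within the scatter). Compound 4 is accordingly expected to give about 900 nM in this assay, with a range from 350 nM to 2500 nM.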

Compound 4, half-maximal inhibitory concentration: 400 nM
Estimate against measurement, compound 4: 2.3-fold (0.35 log units) above; the range from low to high includes it.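

In this assay, 3-bromophenyl in place of 2-bromophenyl gives a 2.3-fold lower number from compound 3 to compound 4 (0.36 log units; beyond the scatter). Among the compounds shown here, this is the first read step, and it shows that with the same atoms, the place of the bromine on the phenyl ring alone shifts the read-out beyond the scatter. No available data bear on a reason for this step. Steps to compound 1 and compound 2 cannot be read. As far as these compounds go, whether an amine in place of the bromine, or a longer chain to the phenoxy group, would keep or change this level remains open.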